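A Second Methoxy on the Amide Aryl Ring

The source may hold more compounds than are shown below. What is called first, only, known or untested is meant among the compounds shown, and "the series" means these compounds.

In a functional assay on A549 cells (Homo sapiens) for inhibition, read by MTT assay, with a stated time of 72 h (a higher number here means a weaker inhibitor, a lower number a stronger inhibitor), compound 2 `COc1ccc(NC(=O)CCC(=O)OCCCCCCSc2ccc([N+](=O)[O-])c3nonc23)cc1` gives 6480 nM, the higher of the two numbers measured, with compound 1 `O=C(CCC(=O)OCCCCCCSc1ccc([N+](=O)[O-])c2nonc12)Nc1cccc(Cl)c1` nearest at 5290 nM. Going by the values given here, the single step between them, a 1.2-fold higher number from compound 1 to compound 2 (0.09 log units; within the scatter), stays within the scatter. Compound 3 `COc1ccc(NC(=O)CCC(=O)OCCCCCCSc2ccc([N+](=O)[O-])c3nonc23)cc1OC` differs from compound 2 by methoxy in place of hydrogen on an aromatic carbon. Among the compounds with values here, only one measured step touches this aryl ring, and it was a 1.2-fold higher number from compound 1 to compound 2 (0.09 log units; within the scatter), so no movement beyond the scatter is expected. The expected step is a 1.0-fold higher number from compound 2 to compound 3 (0.00 log units; within the scatter). Compound 3 is estimated at 6500 nM, with a range from 3000 nM to 14000 nM.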

Compound 3, half-maximal inhibitory concentration: 3890 nM
Compound 3: middle estimate off by 1.7-fold (0.22 log units), on the high side, within the range that was stated.
By their numbers in this assay, from the lowest: compounds 3, 1 and 2 (each within the scatter of the next).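

In this assay, going by these compounds alone, the added methoxy, ortho to a methoxy group on the aryl ring, gives a 1.7-fold lower number from compound 2 to compound 3 (0.22 log units; within the scatter) and so adds a first reading at this position, one that stays within the scatter. The change from 3-chlorophenyl to 3,4-dimethoxyphenyl gives a 1.4-fold lower number from compound 1 to compound 3 (0.13 log units; within the scatter) and also stays within the scatter, so these numbers do not tell the three aryl groups apart. Nothing at hand explains this result.

Going by these compounds, whether an amine or a carboxylic acid in place of the added methoxy would move the number beyond the scatter remains open.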